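The source may report more compounds than this note shows. Statements on the series, on what has been measured and on what is new or still open speak of the compounds shown alone.

Compound 2, `COc1ccc(C(=O)/C=C/c2ccc(OCc3cn(Cc4ccccc4)nn3)cc2)cc1`, gives 70% in a functional assay on MCF7 cells (Homo sapiens) for inhibition, read by MTT assay, with a stated time of 48 h, tested at 10 uM (a lower number here means less inhibition of growth, a higher number more inhibition of growth at the concentration tested), the highest of the two numbers in hand; compound 1, `O=C(/C=C/c1ccc(OCc2cn(Cc3ccccc3)nn2)cc1)c1ccc(Br)cc1`, gives 34% in this assay. Among the measured compounds shown here, the single measured step between them, a number 36 percentage points higher from compound 1 to compound 2 (beyond the scatter), shows that the group on this ring carbon moves the number far beyond the scatter. Compound 3, `O=C(/C=C/c1ccc(OCc2cn(Cc3ccccc3)nn2)cc1)c1ccc([N+](=O)[O-])cc1`, differs from compound 2 by nitro in place of methoxy on an aromatic carbon. The measured step bears on this change only in that it concerns the same position: it exchanged bromo for methoxy, not methoxy for nitro, so it tells the size the number can swing but not where nitro lands. With methoxy at the top of the pair and bromo far lower, a step downward is more likely than not, with wide uncertainty. Compound 3 is therefore expected to give about 45% in this assay, within 20% to 75%, meaning an expected step of a number 25 percentage points lower from compound 2 to compound 3 (beyond the scatter).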

Compound 3, percent growth inhibition at one concentration: "not active" (no number reported)
Compound 3 has no reported number here, so the estimate cannot be set against anything.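

In this assay, among the compounds shown here, compound 3 is reported as not active without a number, so no step from compound 2 to compound 3 can be read. Nothing given here bears on that result. The compounds shown leave open how nitro compares numerically with methoxy and bromo at this ring position.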